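This account rests on a few compounds, and the source may have more. Where it says the series, first, only, none or still open, it means among the compounds named here.

Measured in an ADME assay on Caco-2 cells (Homo sapiens) for permeability, in the apical to basolateral direction; on this read-out lower numbers stand for lower permeability and higher numbers for higher permeability:
Compound 1 `COc1ccc(-c2cc(Cl)c3c(N)ncnn23)cc1N1CCN(C(C)=O)C(C)(C)C1=O`: 170 nm/s
Compound 2 `CC(=O)N1CCN(c2cc(-c3cc(Cl)c4c(N)ncnn34)ccc2S(C)(=O)=O)C(=O)C1(C)C`: "not determined" (no result reported)
Compound 3 `CC(=O)N1CCN(c2cc(-c3cc(Cl)c4c(N)ncnn34)ccc2C(C)O)C(=O)C1(C)C`: 31 nm/s

Of the two numbers available, compound 3 holds the lower, and compound 2 offers no number to compare. Compound 4 `CC(=O)N1CCN(c2cc(-c3cc(Cl)c4c(N)ncnn34)ccc2C#N)C(=O)C1(C)C` differs from compound 3 in one place, with cyano in place of 1-hydroxyethyl on an aromatic carbon.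

For the measured compounds named here, only one measured step bears on this change: a 5.5-fold lower number from compound 1 to compound 3 (0.74 log units; beyond the scatter), which lies beyond the scatter and is the step in which 1-hydroxyethyl took the place of methoxy. In the step to compound 4 the same group leaves, but cyano has not been measured in this series, so that step is only an indirect guide. A rise in this assay is therefore expected, similar to or somewhat smaller than the earlier step in size. The expected step is a 3.5-fold higher number from compound 3 to compound 4 (0.55 log units; beyond the scatter). Compound 4 is estimated at 110 nm/s, within an expected range of 40 nm/s to 280 nm/s.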

Compound 4, apparent permeability: 200 nm/s
Compound 4: middle estimate off by 1.8-fold (0.26 log units), on the low side; the measured number falls inside the stated range.
By their numbers in this assay, from the lowest: compound 3; then compounds 1 and 4 (each within the scatter of the next).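

At this position, ortho to a large group and para to a large group, the low number of compound 3 does not carry over to every group that replaces methoxy: in this assay, cyano in place of 1-hydroxyethyl gives a clear rise (a 6.5-fold higher number from compound 3 to compound 4 (0.81 log units; beyond the scatter)). Cyano in place of methoxy gives no change beyond the scatter (a 1.2-fold higher number from compound 1 to compound 4 (0.07 log units; within the scatter)), so among these three compounds only the one bearing 1-hydroxyethyl, also the only one of the three groups counted with a hydrogen-bond donor, stands apart. No supporting data bear on why these groups read as they do.

The compounds shown leave open whether the hydrogen-bond donor itself goes with the lower number, since a hydroxymethyl or an amine at this position would be needed to test it. As far as these compounds go, how a carboxylic acid or a longer ether chain would read at this position also remains open.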